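Methylating the hydroxy group of compound 1

The compounds below may be only part of what the source reports. "The series", "measured", "known", "first", "only" and "open" are said of these compounds alone.

In a functional assay on PC-3 cells (Homo sapiens) for inhibition, read by sulforhodamine B assay, with a stated time of 48 h, tested at 100 uM (a higher number here means a weaker effect of the compound at the concentration tested, a lower number a stronger effect), compound 1 `O=C(Nc1cccc(-n2cc(-c3ccncc3)c(-c3cc(O)cc(Cl)c3)n2)c1)Nc1ccc(Cl)c(C(F)(F)F)c1` gives -83%, the lowest of the two numbers measured. Compound 2 `O=C(Nc1cccc(-n2cc(-c3ccncc3)c(-c3cc(O)cc(Cl)c3)n2)c1)Nc1ccc(Cl)c(Cl)c1` gives -35%; the step of a number 48 percentage points higher from compound 1 to compound 2 (beyond the scatter) is large but concerns the trifluoromethyl and not the hydroxy. Compound 3 `COc1cc(Cl)cc(-c2nn(-c3cccc(NC(=O)Nc4ccc(Cl)c(C(F)(F)F)c4)c3)cc2-c2ccncc2)c1` differs from compound 1 by methyl in place of hydrogen on an oxygen on an aromatic ring, hydroxy to methoxy. Among the compounds with values here, no measured step touches this oxygen, so nothing here tells the size of that change, and the working expectation is a step within the scatter. Compound 3 is therefore estimated at -70%, range -100% to -30%, an expected step of a number 13 percentage points higher from compound 1 to compound 3 (beyond the scatter).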

Compound 3, a percentage reported as activity, at one concentration (the size of the read-out at that concentration, not a potency): -15%
Beside the measured number, compound 3's estimate is 55 percentage points below it; the whole stated range lies below it.
By their numbers in this assay, from the lowest: compound 1; then compound 2; then compound 3.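

In this assay the change from hydroxy to methoxy gives a number 68 percentage points higher from compound 1 to compound 3 (beyond the scatter) and so shows that this oxygen is a sensitive place in the series: a single added methyl removes much of the read-out. Against methoxy, the free hydroxy of compound 1 goes with the lower number. Nothing shown here explains this step.

As far as these compounds go, whether an amine or an ethoxy at this place would read like hydroxy or like methoxy stays open. So does whether the same change on compound 2 would give a step of similar size.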